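The compounds below may be only part of what the source reports. "The series", "measured", "known", "first", "only" and "open" are said of these compounds alone.

Compound 1 `Cc1n[nH]cc1-c1cccc2c1CCC2c1ncc[nH]1` is the only one of the three measured compounds to give a number in a functional assay on CHO cells for agonist activity at Alpha-1D adrenergic receptor (Homo sapiens), read by FLIPR and calcium flux (a higher number here means that more compound is needed for the effect, a lower number that less compound is needed), where compound 1 gives 634 nM. Compound 2 `CS(=O)(=O)Nc1cccc2c1CCC2c1ncc[nH]1` reaches only a limit of this assay, with compound 2 reported as > 10000 nM. Compound 3 `c1cncc(-c2cccc3c2CCC3c2ncc[nH]2)c1` likewise reaches only a limit, compound 3 being reported as > 10000 nM. Both therefore sit at the limit of > 10000 nM in this assay, at which 2 of the 3 values shown sit. The change from compound 1 to compound 4 `c1cc(-c2nccs2)c2c(c1)C(c1ncc[nH]1)CC2` is 1,3-thiazol-2-yl in place of 3-methyl-1H-pyrazol-4-yl on an aromatic carbon. For the measured compounds named here, two measured steps bear on it, each replacing the same group on the same shared core: an at least 15-fold higher number from compound 1 to compound 2 (1.19 log units; beyond the scatter) and an at least 15-fold higher number from compound 1 to compound 3 (1.19 log units; beyond the scatter). Both are large and point the same way, so a large rise in this assay is expected for compound 4, namely a 13-fold higher number from compound 1 to compound 4 (1.10 log units; beyond the scatter). Compound 4 is thus estimated at 8000 nM, within a range of 2000 nM to 30000 nM.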

Compound 4, half-maximal effective concentration: 3190 nM
For compound 4 the middle estimate is 2.5-fold (0.40 log units) above the measured one; the measured number falls inside the stated range.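

Replacing 3-methyl-1H-pyrazol-4-yl with 1,3-thiazol-2-yl on this aromatic carbon does not carry compound 4 to the limit of this assay, with a 5.0-fold higher number from compound 1 to compound 4 (0.70 log units; beyond the scatter). The entering ring has 0 hydrogen-bond donors, so a donor on this group is not required for a measurable number. The 1,3-thiazol-2-yl group also separates clearly from the other two replacements, with an at least 3.1-fold lower number from compound 3 to compound 4 (0.49 log units; beyond the scatter) and an at least 3.1-fold lower number from compound 2 to compound 4 (0.49 log units; beyond the scatter).

The compounds shown leave open whether the methyl group of compound 1 contributes to its number. They also leave open how a pyrazole without that methyl, or an oxazol-2-yl ring, would compare at this place.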